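Piperidinyl in place of dimethylamino on the aminoethyl chain

The source may report more compounds than this note shows. Statements on the series, on what has been measured and on what is new or still open speak of the compounds shown alone.

Going by the values given here, compound 2 `CN(C)CCNc1ccc(Cn2c(=O)[nH]c3c(N)nc(C(F)(F)F)cc32)cn1` is the only compound here with a plain number in an in vitro ADME assay on microsomes from liver (Homo sapiens) for pharmacokinetics; a lower number here means slower removal, a higher number faster removal of the compound: compound 2 gives 9 mL.min-1.g-1. Compound 1 `Nc1nc(C(F)(F)F)cc2c1[nH]c(=O)n2Cc1ccc(NCc2ccccc2)nc1` gives only a limit in this assay, namely < 8 mL.min-1.g-1. Among the compounds with values here, the single measured step, an at least 1.1-fold higher number from compound 1 to compound 2 (0.05 log units; that floor lies within the scatter), lies within the scatter. Compound 3 `Nc1nc(C(F)(F)F)cc2c1[nH]c(=O)n2Cc1ccc(NCCN2CCCCC2)nc1` differs from compound 2 by piperidin-1-yl in place of dimethylamino on a saturated chain carbon, two bonds along the chain from a nitrogen on an aromatic ring. Within the data shown here, no measured step covers this change, so the expectation is anchored on compound 2 and its value of 9 mL.min-1.g-1. Compound 3 is expected to show a 1.6-fold higher number from compound 2 to compound 3 (0.19 log units; within the scatter), an estimated 14 mL.min-1.g-1 with a range from 7 mL.min-1.g-1 to 30 mL.min-1.g-1.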

Compound 3, intrinsic clearance in microsomes in the Homo sapiens assay: 13 mL.min-1.g-1
The estimate for compound 3 lay 1.1-fold (0.03 log units) above the measured number; low and high end bracket the measured number.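

In a physicochemical assay for lipophilicity (on this read-out lower numbers stand for lower lipophilicity and higher numbers for higher lipophilicity), compound 2 gives 0.7 and compound 3 gives 1.3. With piperidin-1-yl in place of dimethylamino on a saturated chain carbon, two bonds along the chain from a nitrogen on an aromatic ring, the physicochemical assay shows a number 0.60 log units higher from compound 2 to compound 3 (beyond the scatter), whereas the Homo sapiens assay shows a 1.4-fold higher number from compound 2 to compound 3 (0.16 log units; within the scatter). Compound 1 gives only a limit in the Homo sapiens assay: the limit of < 8 mL.min-1.g-1 in the Homo sapiens assay, at which 1 of the 3 values shown sits. With (piperidin-1-yl)methyl in place of phenyl on a saturated chain carbon bound to a nitrogen on an aromatic ring, the Homo sapiens assay shows an at least 1.6-fold higher number from compound 1 to compound 3 (0.21 log units; that floor lies within the scatter). As far as these compounds go, whether morpholin-4-yl or a longer chain in this place would move the number in the Homo sapiens assay beyond the scatter stays open.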